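A few compounds are considered here, and "the series" means these few. Any claim that something is new, unique, unknown or untested is made for them only; others in the source may bear on it.

Series notes, step from compound 3 to compound 4.

Compound 3 `COc1cc2ncnc(N3CCc4ccccc43)c2cc1NC(=O)/C=C/CN(C)C` gives 3370 nM in a functional assay on MCF7 cells (Homo sapiens) for antiproliferative activity, read by MTT assay, with a stated time of 72 h; on this read-out lower numbers stand for stronger inhibition and higher numbers for weaker inhibition; of the three numbers in hand it is the smallest, but the comparison with compound 2 is flat: the step of a 1.2-fold lower number from compound 2 to compound 3 (0.08 log units; within the scatter) is within the scatter. Compound 2 `CC/C=C/C(=O)Nc1cc2c(N3CCc4ccccc43)ncnc2cc1OC` gives 4030 nM in this assay. Compound 1 `C=C(C)C(=O)Nc1cc2c(N3CCc4ccccc43)ncnc2cc1OC` gives 11100 nM in this assay, and the steps of a 2.8-fold lower number from compound 1 to compound 2 (0.44 log units; beyond the scatter) and a 3.3-fold lower number from compound 1 to compound 3 (0.52 log units; beyond the scatter) are the only ones beyond the scatter in the set.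

Compound 4 `COc1cc2ncnc(N3CCc4ccccc43)c2cc1NC(=O)/C=C/CN1CCCC1` differs from compound 3 by pyrrolidin-1-yl in place of dimethylamino on a saturated chain carbon bound to a double-bonded chain carbon. Among the measured compounds shown here, the single measured step at that place, a 1.2-fold lower number from compound 2 to compound 3 (0.08 log units; within the scatter), is within the scatter, and no measured pair swaps one amine for another on the saturated chain carbon bound to a double-bonded chain carbon. The two steps beyond the scatter both start from compound 1 and alter the acyl fragment itself, not the amine, so they do not bear directly on this change.

On that basis no step beyond the scatter is expected in this assay from compound 3 to compound 4, a 1.1-fold lower number from compound 3 to compound 4 (0.05 log units; within the scatter). Compound 4 is estimated at 3000 nM in this assay, with a range from 1200 nM to 7500 nM.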

Compound 4, half-maximal inhibitory concentration: 1510 nM
Compound 4: the middle estimate sits 2.0-fold (0.30 log units) above what was measured; the measured number falls inside the stated range.
By their numbers in this assay, from the lowest: compound 4; then compounds 3 and 2 (each within the scatter of the next); then compound 1.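

In this assay, among the compounds shown here, the amine on the saturated chain carbon bound to a double-bonded chain carbon now shows an effect: pyrrolidin-1-yl in place of dimethylamino gives a 2.2-fold lower number from compound 3 to compound 4 (0.35 log units; beyond the scatter), the first step beyond the scatter from one amine to another, whereas the earlier change from methyl to dimethylamino gave only a 1.2-fold lower number from compound 2 to compound 3 (0.08 log units; within the scatter). Pyrrolidin-1-yl in place of methyl gives a 2.7-fold lower number from compound 2 to compound 4 (0.43 log units; beyond the scatter), so among these compounds an amine at this place separates from methyl only in the pyrrolidin-1-yl form, with compound 3 going against any general amine effect, and the replacement of the 1-methylethenyl group of compound 1 by 3-(pyrrolidin-1-yl)prop-1-en-1-yl gives a 7.4-fold lower number from compound 1 to compound 4 (0.87 log units; beyond the scatter), the widest step in the set. No measurement at hand accounts for the step from dimethylamino to pyrrolidin-1-yl.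

The compounds shown leave open whether the step follows the ring itself or the additional carbon atoms, a question that diethylamino, an open-chain amine, could help settle. Piperidin-1-yl and morpholin-4-yl at the same place would show whether ring size or a second ring hetero atom changes the number.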